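Replacing the Tetrazolyl Group on Sulfur with a Smaller Ring

The source may report more compounds than this note shows. Statements on the series, on what has been measured and on what is new or still open speak of the compounds shown alone.

Compound 3 `Cn1nnnc1SCC(=O)Nc1ccc(-c2nc(-c3ccccc3)c(-c3ccccc3)n2C)cc1` gives the highest of the three measured numbers in a functional assay on HT-29 cells (Homo sapiens) for cytotoxicity, read by MTT assay, with a stated time of 24 h, tested at 32 ug/mL (a lower number here means a weaker effect, a higher number a stronger effect of the compound at the concentration tested), where compound 3 reaches 84%. Compound 1 `Cn1c(-c2ccc(NC(=O)CSc3nc4cc(Cl)ccc4o3)cc2)nc(-c2ccccc2)c1-c1ccccc1` gives 61.9% and compound 2 `Cc1ccc2oc(SCC(=O)Nc3ccc(-c4nc(-c5ccccc5)c(-c5ccccc5)n4C)cc3)nc2c1` gives 59.5%. For the measured compounds named here, two measured steps bear on the present change: a number 22.1 percentage points higher from compound 1 to compound 3 (beyond the scatter) and a number 24.5 percentage points higher from compound 2 to compound 3 (beyond the scatter), both putting the 1-methyl-1H-tetrazol-5-yl group on the sulfur in place of a 1,3-benzoxazol-2-yl group, while a number 2.4 percentage points lower from compound 1 to compound 2 (within the scatter) shows a swap on that group made no difference. Compound 4 `Cn1c(-c2ccc(NC(=O)CSC3=NCCS3)cc2)nc(-c2ccccc2)c1-c1ccccc1` carries a group of 5 heavy atoms (3 carbon, 1 nitrogen, 1 sulfur; one five-membered non-aromatic ring with 2 hetero atoms) in place of a group of 6 heavy atoms (2 carbon, 4 nitrogen; one five-membered aromatic ring with 4 hetero atoms), on a sulfur. Going by the values given here, no measured step removes the tetrazolyl group itself, so the direction is uncertain, and the entering ring is again five-membered, so only a modest step is expected. For compound 4 a value of 70% is expected, between 50% and 90%. This means an expected step of a number 14 percentage points lower from compound 3 to compound 4 (beyond the scatter).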

Compound 4, a percentage reported as activity, at one concentration (the size of the read-out at that concentration, not a potency): 59.4%
Beside the measured number, compound 4's estimate is 10.6 percentage points above it; the range from low to high includes it.
By their numbers in this assay, from the lowest: compounds 4, 2 and 1 (each within the scatter of the next); then compound 3.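

In this assay, the five-membered non-aromatic ring does not keep the level of the 1-methyl-1H-tetrazol-5-yl group, with a number 24.6 percentage points lower from compound 3 to compound 4 (beyond the scatter). It instead matches the two larger 1,3-benzoxazol-2-yl compounds, with a number 0.1 percentage points lower from compound 2 to compound 4 (within the scatter) and a number 2.5 percentage points lower from compound 1 to compound 4 (within the scatter), so a five-membered ring on the sulfur is not enough by itself, and among these four compounds only compound 3 stands apart. Nothing measured here gives a reason for this difference.

Open, on these data alone, is whether another aromatic ring, such as 1-methyl-1H-imidazol-2-yl, or an open chain ending in a carboxylic acid on the sulfur would match compound 3 or the other three.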